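This account rests on a few compounds, and the source may have more. Where it says the series, first, only, none or still open, it means among the compounds named here.

Compound 1 `CC(O)(CSc1ccc(S(F)(F)(F)(F)F)cc1)C(=O)Nc1ccc(C#N)c(C(F)(F)F)c1`: 16900 nM
Compound 2 `CC(O)(CSc1ccc(F)cc1)C(=O)Nc1ccc(S(F)(F)(F)(F)F)cc1`: 12500 nM
Compound 3 `CC(O)(COc1cccc(S(F)(F)(F)(F)F)c1)C(=O)Nc1ccc(S(F)(F)(F)(F)F)cc1`: 12000 nM

In a functional assay on LNCaP cells (Homo sapiens) for antiproliferative activity, read by propidium iodide staining, with a stated time of 96 h (on this read-out lower numbers stand for stronger inhibition and higher numbers for weaker inhibition), compound 3 gives 12000 nM, a value within the usual scatter of those of compound 2 and compound 1. The three compounds therefore cannot be told apart on these numbers. Compound 4 `CC(O)(COc1cccc(C(F)(F)F)c1)C(=O)Nc1ccc(S(F)(F)(F)(F)F)cc1` changes compound 3 in one place, where trifluoromethyl enters on an aromatic carbon: a group of 4 heavy atoms (1 carbon, 3 fluorine; no ring) in place of a group of 6 heavy atoms (5 fluorine, 1 sulfur; no ring), on an aromatic carbon. Within the data shown here, no measured pair shows this change, so the expectation rests on compound 3 and its value of 12000 nM. No step beyond the scatter is expected, in either direction. The expected step is small: no change at the digits printed from compound 3 to compound 4 (within the scatter). For compound 4 the estimated value is 12000 nM, with an expected range from 5000 nM to 25000 nM.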

Compound 4, half-maximal inhibitory concentration: 24700 nM
Beside the measured number, compound 4's estimate is 2.1-fold (0.31 log units) below it, and the stated range covers the measured number.
By their numbers in this assay, from the lowest: compounds 3, 2, 1 and 4 (each within the scatter of the next, the first and the last beyond it).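

In this assay, among these compounds, the exchange at this aromatic carbon gives a 2.1-fold higher number from compound 3 to compound 4 (0.31 log units; beyond the scatter), a modest step but one beyond the usual scatter, which the earlier compounds, all within scatter of one another, could not show. This position therefore responds to the change: with trifluoromethyl in place of the larger sulfur-bearing group, inhibition is weaker. Nothing shown here explains the step. As far as these compounds go, whether chlorine, an amine or a carboxylic acid at this carbon would give a stronger or weaker result remains open.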